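The source may hold more compounds than are shown below. What is called first, only, known or untested is meant among the compounds shown, and "the series" means these compounds.

In a functional assay on KB cells (Homo sapiens) for antiproliferative activity, read by sulforhodamine B assay, with a stated time of 3 days (a lower number here means a stronger inhibitor of growth, a higher number a weaker inhibitor of growth), three amides built on the shared core have been measured. Compound 1 `COc1ccc(NC(=O)c2cccc(Nc3ncc(F)c(Nc4ccc(F)cc4)n3)c2)cc1` gives > 10000 nM, which is a limit of the assay and not a number. Compound 2 `O=C(Nc1cc(Cl)cc(Cl)c1)c1cccc(Nc2ncc(F)c(Nc3ccc(F)cc3)n2)c1` gives 20100 nM. Compound 3 `Cn1ccnc1NC(=O)c1cccc(Nc2ncc(F)c(Nc3ccc(F)cc3)n2)c1` gives 14600 nM, and it stands level with compound 2 on the numbers: the comparison shows a 1.4-fold lower number from compound 2 to compound 3 (0.14 log units; within the scatter).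

Compound 4 `COc1cc(NC(=O)c2cccc(Nc3ncc(F)c(Nc4ccc(F)cc4)n3)c2)cc(OC)c1` keeps the core of compound 3 and changes one group: 3,5-dimethoxyphenyl in place of 1-methyl-1H-imidazol-2-yl on an amide-type nitrogen. In words, 3,5-dimethoxyphenyl takes the place of 1-methyl-1H-imidazol-2-yl on an amide-type nitrogen.

The closest guide is the exchange of 3,5-dichlorophenyl for the same imidazolyl group, which gave a 1.4-fold lower number from compound 2 to compound 3 (0.14 log units; within the scatter). The two steps from the 4-methoxyphenyl of compound 1 say little about size, as they read a step that the limit leaves unreadable from compound 1 to compound 2 and a step that the limit leaves unreadable from compound 1 to compound 3. Compound 4 pairs the 3,5-substitution seen in compound 2 with the methoxy groups seen in compound 1, so no step beyond the scatter is expected in this assay. The estimated change is a 1.0-fold higher number from compound 3 to compound 4 (0.01 log units; within the scatter). For compound 4 the expected value is 15000 nM, with an estimated range of 7000 nM to 30000 nM.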

Compound 4, concentration for 50% growth inhibition: 15500 nM
Beside the measured number, compound 4's estimate is 1.0-fold (0.01 log units) below it; the measured number falls inside the stated range.
By their numbers in this assay, from the lowest: compounds 3, 4 and 2 (each within the scatter of the next).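

In this assay, for the compounds shown here, the 3,5-dimethoxyphenyl group on an amide-type nitrogen gives a 1.1-fold higher number from compound 3 to compound 4 (0.03 log units; within the scatter) and also a 1.3-fold lower number from compound 2 to compound 4 (0.11 log units; within the scatter) and so adds a third readable group at this position, where the earlier compounds offered only one readable pair. The exchange holds the number level whether 3,5-dimethoxyphenyl, with 10 heavy atoms and one six-membered aromatic ring of carbon only, replaces 1-methyl-1H-imidazol-2-yl, with 6 heavy atoms and one five-membered aromatic ring with 2 hetero atoms, or replaces 3,5-dichlorophenyl, so neither the ring type nor the change from chlorine to methoxy at the same places registers beyond the scatter among compounds 2, 3 and 4. The steps from compound 1 cannot be read because its value (> 10000 nM) is a limit and not a number: the limit of > 10000 nM in this assay, at which 1 of the 4 values shown sits.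

Still open, as far as these compounds go, is whether a group of another kind on this amide-type nitrogen, such as a piperazine, a carboxylic acid or a longer alkyl chain, would move the number beyond the scatter. Also open, from the compounds shown here alone, is whether a change elsewhere on the shared core, such as an amine in place of the 4-fluorophenyl group, would do so.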